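A few compounds are considered here, and "the series" means these few. Any claim that something is new, unique, unknown or untested is made for them only; others in the source may bear on it.

Of the compounds shown here, two have so far been measured in an ADME assay on RAW264.7 cells (Mus musculus) for cytotoxicity, read by MTT assay, with a stated time of 48 h; a higher number here means that more compound is tolerated, a lower number that less compound is tolerated. Compound 1, `C#CCN(c1nc(-c2cccc(Br)c2)no1)C1CCCCC1`, gives 31.8 ug/mL in this assay. Compound 2, `CC(=O)OC[C@H]1O[C@H](OC[C@@H](Cn2cc(CN(c3nc(-c4ccc(F)cc4)no3)C3CCCCC3)nn2)OC(C)=O)C=C[C@@H]1OC(C)=O`, gives 31.5 ug/mL in this assay; its number is within the scatter of that of compound 1, so the two sit together. Compound 3, `CC(=O)OC[C@H]1O[C@H](OC[C@@H](Cn2cc(CN(c3nc(-c4ccccc4)no3)C3CCCCC3)nn2)OC(C)=O)C=C[C@@H]1OC(C)=O`, has not yet been measured. The difference is hydrogen in place of fluoro on an aromatic carbon. Among the measured compounds shown here, no measured pair shows such a step, so no step beyond the scatter is expected either way. Compound 3 is therefore estimated at 32 ug/mL in this assay, between 16 ug/mL and 64 ug/mL, which would be a step of a 1.0-fold higher number from compound 2 to compound 3 (0.01 log units; within the scatter).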

Compound 3, half-maximal cytotoxic concentration: 28.6 ug/mL
For compound 3 the middle estimate is 1.1-fold (0.05 log units) above the measured one; the measured number falls inside the stated range.
By their numbers in this assay, from the lowest: compounds 3, 2 and 1 (each within the scatter of the next).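

In this assay, among the compounds shown here, hydrogen in place of fluoro on an aromatic carbon, para to a large group, gives a 1.1-fold lower number from compound 2 to compound 3 (0.04 log units; within the scatter) and so provides the first direct reading at this position: 4-fluorophenyl and phenyl cannot be told apart here. Nothing available explains this result. The compounds shown leave open whether a larger or differently built group at this position, such as methoxy, an amine or a carboxylic acid, would move the number beyond the scatter. They also leave open whether chloro or bromo would do so.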